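The compounds below may be only part of what the source reports. "The series", "measured", "known", "first", "only" and "open" are said of these compounds alone.

Three ureas sharing one core have been measured. Compound 1 `CCOC(=O)c1cccc(NC(=O)N[C@H](C)c2ccccc2)c1` gives 99% in an ADME assay on the whole organism with Oryza sativa as the target, tested at 0.1 uM (on this read-out higher numbers stand for a weaker effect at the one concentration tested and lower numbers for a stronger effect), compound 2 `COc1cccc(NC(=O)N[C@H](C)c2ccccc2)c1` gives 104% and compound 3 `C[C@@H](NC(=O)Nc1cccc(Cl)c1)c1ccccc1` gives 97%. Compound 3 sits nearest to compound 1, with a number 2 percentage points lower from compound 1 to compound 3 (within the scatter), while a number 7 percentage points lower from compound 2 to compound 3 (within the scatter); all three numbers lie within the scatter of one another. Compound 4 `C[C@@H](NC(=O)Nc1cccc(I)c1)c1ccccc1` differs from compound 3 by iodo in place of chloro on an aromatic carbon. For the measured compounds named here, the only measured steps that bear on this are the two that bring chloro in, and neither moved the number beyond the scatter, so no change beyond the scatter is expected in this assay here. The step from compound 3 to compound 4 is therefore estimated as no change at the digits printed from compound 3 to compound 4 (within the scatter). For compound 4 the expected value is 97%, with a range from 87% to 107%.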

Compound 4, a percentage reported as activity, at one concentration (the size of the read-out at that concentration, not a potency): 81%
Beside the measured number, compound 4's estimate is 16 percentage points above it; the measured number lies below the stated range.
By their numbers in this assay, from the lowest: compound 4; then compounds 3, 1 and 2 (each within the scatter of the next).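

At this place on the ring, the read-out in this assay does respond to the substituent: iodo brings a number 16 percentage points lower from compound 3 to compound 4 (beyond the scatter), along with a number 23 percentage points lower from compound 2 to compound 4 (beyond the scatter) and a number 18 percentage points lower from compound 1 to compound 4 (beyond the scatter), whereas the steps among chloro, methoxy and ethoxycarbonyl all stayed within the scatter. Compound 4 alone stands apart, with the strongest effect of the four at the one concentration tested. Nothing available here explains the difference between iodo and chloro. As far as these compounds go, whether bromo, an amine or a carboxylic acid at this place would also move the number remains open, as does whether the step from chloro to iodo holds at other concentrations.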